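A Larger Ring Swap in a Level Toxicity Series

The source may hold more compounds than are shown below. What is called first, only, known or untested is meant among the compounds shown, and "the series" means these compounds.

Of the compounds shown here, three that share one core have been measured in a toxicity assay on MT4 cells (Homo sapiens) for cytotoxicity, read by MTT assay (on this read-out lower numbers stand for higher toxicity in this test and higher numbers for lower toxicity in this test), and their numbers sit close together. Compound 1 (`Cc1cc(-c2ccccc2F)cc(C)c1Oc1cc(N)nc(Nc2ccc(C#N)cc2)n1`) gives 29300 nM while compound 2 (`Cc1cc(-c2ccccc2Cl)cc(C)c1Oc1cc(N)nc(Nc2ccc(C#N)cc2)n1`) gives 25100 nM and compound 3 (`Cc1cc(-c2ccccc2F)ccc1Oc1cc(N)nc(Nc2ccc(C#N)cc2)n1`) gives 29500 nM and so stands level with both others within the scatter.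

The next compound differs from compound 3 at one place. Compound 4 (`Cc1cc(-c2ccc(C#N)c(F)c2)ccc1Oc1cc(N)nc(Nc2ccc(C#N)cc2)n1`) carries 4-cyano-3-fluorophenyl in place of 2-fluorophenyl on an aromatic carbon.

For the measured compounds named here, two measured steps bear on this change. Chloro in place of fluoro gave a 1.2-fold lower number from compound 1 to compound 2 (0.07 log units; within the scatter) and hydrogen in place of methyl gave a 1.0-fold higher number from compound 1 to compound 3 (0.00 log units; within the scatter) so neither edit left the scatter. Going by the values given here, both steps are small, but neither is a close guide, since no measured compound carries the 4-cyano-3-fluorophenyl group. No step beyond the scatter is therefore expected in this assay and the estimated change is a 1.5-fold lower number from compound 3 to compound 4 (0.17 log units; within the scatter) with no firm direction. For compound 4 the estimated value is 20000 nM with an expected range from 7000 nM to 50000 nM as a deliberately wide allowance for the new group.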

Compound 4, half-maximal cytotoxic concentration: 6600 nM
Compound 4: the middle estimate sits 3.0-fold (0.48 log units) above what was measured; measured number outside the range, below it.
By their numbers in this assay, from the lowest: compound 4; then compounds 2, 1 and 3 (each within the scatter of the next).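

In this assay, for the compounds shown here, the group on this aromatic carbon proves able to shift the number: 4-cyano-3-fluorophenyl in place of 2-fluorophenyl gives a 4.5-fold lower number from compound 3 to compound 4 (0.65 log units; beyond the scatter), the only step in this set that lies beyond the scatter. The earlier edits, chloro in place of fluoro and hydrogen in place of methyl, left the numbers level, so they gave no sign that this series could move at all; the larger ring swap shows that it can, and in the direction of higher toxicity in this test. Nothing available accounts for the shift.

This single swap changes two things at once, since a nitrile enters the ring and the fluorine sits at a different ring position, so the compounds shown cannot say which of the two goes with the lower number. Plain 4-cyanophenyl and 3-fluorophenyl at this carbon would pull the two apart, and a ring carrying an amine or a carboxylic acid in place of the nitrile would show whether the nitrile itself matters.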